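Working notes: replacing the carbonyl substituent in the channel binding assay

The compounds below may be only part of what the source reports. "The series", "measured", "known", "first", "only" and "open" are said of these compounds alone.

Measured so far in a binding assay on LtK cells with ATP-sensitive inward rectifier potassium channel 11 (Homo sapiens) as the target; a lower number here means that less compound is needed, a higher number that more compound is needed for the effect:
compound 1 `CCC(=O)Nc1c(C(O)(C(F)(F)F)C(F)(F)F)ccc2ccccc12`: 15 nM
compound 2 `O=C(NCCCCCCCl)Nc1c(C(O)(C(F)(F)F)C(F)(F)F)ccc2ccccc12`: 4840 nM

Compound 2 stands at the higher of the two numbers; its nearest neighbour is compound 1, with a 320-fold higher number from compound 1 to compound 2 (2.51 log units; beyond the scatter). Compound 3 `O=C(Nc1c(C(O)(C(F)(F)F)C(F)(F)F)ccc2ccccc12)c1cccc(C(F)(F)F)c1` differs from compound 2 by 3-(trifluoromethyl)phenyl in place of (6-chlorohexyl)amino on a carbonyl carbon. Among the measured compounds shown here, the only measured step bearing on this carbonyl position is a 320-fold higher number from compound 1 to compound 2 (2.51 log units; beyond the scatter), which shows a carbon substituent giving a much lower number than the amino substituent. In this assay the expected step is a 32-fold lower number from compound 2 to compound 3 (1.51 log units; beyond the scatter), since compound 3 returns to a carbon substituent as compound 1 had in 15 nM. Compound 3 is estimated at 150 nM, within 15 nM to 1500 nM.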

Compound 3, half-maximal effective concentration: 84 nM
For compound 3 the middle estimate is 1.8-fold (0.25 log units) above the measured one, within the range that was stated.
By their numbers in this assay, from the lowest: compound 1; then compound 3; then compound 2.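

In this assay, a carbonyl carbon bearing 3-(trifluoromethyl)phenyl gives a 58-fold lower number from compound 2 to compound 3 (1.76 log units; beyond the scatter), so an aromatic ring on this carbonyl is compatible with a low number. Ethyl still holds the advantage, with a 5.6-fold higher number from compound 1 to compound 3 (0.75 log units; beyond the scatter). No measurement available here explains either step.

The compounds shown leave open whether the high number of compound 2 follows from the amino link or from the 6-chlorohexyl chain. A short ethylamino group on the same carbonyl would separate these two readings.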